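The source may hold more compounds than are shown below. What is called first, only, known or untested is meant among the compounds shown, and "the series" means these compounds.

Among the measured compounds shown here, compound 2 `Cc1cc(NC(=O)Cn2nnc(-c3cccc(C(F)(F)F)c3)n2)n(C2CCCCC2)n1` is one of two compounds measured so far in an assay on HEK293 cells for activation of Kir3.1/Kir3.2 (Homo sapiens), read by thallium flux; a higher number here means a larger maximal response, a lower number a smaller maximal response. In this assay compound 2 gives 86%, and compound 1 `COc1cccc(-c2nnn(CC(=O)Nc3cc(C)nn3C3CCCCC3)n2)c1` gives 76%; these two numbers lie within the usual scatter of each other, so neither can be called larger.

The next compound, compound 3 `Cc1cc(NC(=O)Cn2nnc(-c3ccc(Cl)c(C)c3)n2)n(C2CCCCC2)n1`, is not yet measured. It differs from compound 2 at a single place: 4-chloro-3-methylphenyl in place of 3-(trifluoromethyl)phenyl on an aromatic carbon. For the measured compounds named here, the ring that carries the change is the same six-membered aromatic ring of carbon only that was altered between compound 1 and compound 2.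

That earlier step, trifluoromethyl in place of methoxy on an aromatic carbon, gave a number 10 percentage points higher from compound 1 to compound 2 (within the scatter). Going by the values given here, it is the only measured step that bears on the present one, and it shows that swapping the group on this ring left the maximal response essentially unchanged. The expectation is therefore a step of about a number 6 percentage points lower from compound 2 to compound 3 (within the scatter), not beyond the scatter.

Compound 3 is thus estimated to give 80%, with a range from 65% to 95%.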

Compound 3, largest response reached (Emax), in percent of the reference or control that the assay uses: 89%
The estimate for compound 3 lay 9 percentage points below the measured number, and the stated range covers the measured number.
By their numbers in this assay, from the lowest: compounds 1, 2 and 3 (each within the scatter of the next, the first and the last beyond it).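

In this assay, replacing 3-(trifluoromethyl)phenyl with 4-chloro-3-methylphenyl gives a number 3 percentage points higher from compound 2 to compound 3 (within the scatter), so this position accepts a phenyl ring carrying two groups, with a chlorine among them, and the maximal response stays within the scatter. Among the compounds shown here, the comparison with the 3-methoxyphenyl group gives a number 13 percentage points higher from compound 1 to compound 3 (beyond the scatter), the first step in this small series to exceed the scatter, although only modestly, while compound 2 cannot be separated from either of the other two compounds. No supporting measurement is available to explain this difference between the groups on the phenyl ring.

From the compounds shown here alone, all three compounds carry a substituted phenyl ring at this position, so it remains open whether the maximal response would hold with an amine or a carboxylic acid on that ring, or with a plain phenyl ring carrying no group at all. The rest of the molecule is also the same in all three compounds, so these results say nothing about how much the response depends on the parts of the shared core away from this position.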